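The source may hold more compounds than are shown below. What is called first, only, known or untested is meant among the compounds shown, and "the series" means these compounds.

In a functional assay on KB3 cells (Homo sapiens) for antiproliferative activity, read by MTT assay, with a stated time of 96 h (on this read-out higher numbers stand for weaker inhibition and lower numbers for stronger inhibition), compound 1 `C=C(C)[C@H]1CC=C(C)C2=CO[C@@H](c3ccco3)[C@@H]21` gives 2000 nM and compound 2 `C=C(C)[C@H]1CC(=O)C(C)=C2[C@@H](C(=O)OCC)O[C@@H](c3cccc(Cl)c3Cl)[C@@H]21` gives 5000 nM as the higher of the two numbers, which means weaker inhibition, with a gap beyond the usual scatter. Compound 3 `C=C(C)[C@H]1CC(=O)C(C)=C2[C@@H](C(=O)OCC)O[C@@H](c3ccc(Cl)cc3Cl)[C@@H]21` keeps the core of compound 2 but carries 2,4-dichlorophenyl in place of 2,3-dichlorophenyl on a saturated ring carbon. Going by the values given here, no measured pair shows what this swap does, so a step beyond the scatter is not expected in this assay in either direction. The estimated step (a 1.3-fold lower number from compound 2 to compound 3 (0.10 log units; within the scatter)) is small. Compound 3 is expected at 4000 nM within a range from 1500 nM to 10000 nM in this estimate.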

Compound 3, half-maximal inhibitory concentration: 3000 nM
Estimate against measurement, compound 3: 1.3-fold (0.12 log units) above; measured number inside the range.
By their numbers in this assay, from the lowest: compounds 1, 3 and 2 (each within the scatter of the next, the first and the last beyond it).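

Swapping 2,3-dichlorophenyl for 2,4-dichlorophenyl on the saturated ring carbon gives a 1.7-fold lower number from compound 2 to compound 3 (0.22 log units; within the scatter) in this assay and so leaves the number within the usual scatter. At this position, the two chlorine patterns cannot be told apart on this read-out. Nothing measured here offers an explanation for this result. Still open, going by these compounds, is what an unsubstituted phenyl, or a phenyl carrying a methoxy group or an amine, would do at this same carbon, and whether any change here can move the number beyond the scatter.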